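The compounds below may be only part of what the source reports. "The series", "measured", "known", "first", "only" and "open" are said of these compounds alone.

Measured so far in a functional assay on MCF7 cells (Homo sapiens) for cytotoxicity, read by MTT assay, with a stated time of 2 days, tested at 10 uM; a higher number here means a weaker effect of the compound at the concentration tested, a lower number a stronger effect:
compound 1, `CC(=O)c1cc(-c2ccc(F)cc2)cc2cc(-c3ccc(F)cc3)[nH]c12`: 90.6%
compound 2, `COc1ccc(-c2cc(C(C)=O)c3[nH]c(-c4ccc(F)cc4)cc3c2)cc1`: 52.9%

Among the measured compounds shown here, compound 2 stands lowest of the two numbers, compound 1 being the only neighbour. For the measured compounds named here, the single measured step, a number 37.7 percentage points lower from compound 1 to compound 2 (beyond the scatter), came from methoxy in place of fluoro on an aromatic carbon. Compound 3, `COc1ccc(-c2cc(C(C)=O)c3[nH]c(-c4ccc(OC)cc4)cc3c2)cc1`, repeats that same kind of change on the remaining fluorophenyl of compound 2: methoxy in place of fluoro on an aromatic carbon. That one step bears on it and was large, so a further drop is expected, though likely smaller; the expected step is a number 17.9 percentage points lower from compound 2 to compound 3 (beyond the scatter). Compound 3 is therefore estimated at 35%, within 15% to 60%.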

Compound 3, a percentage reported as activity, at one concentration (the size of the read-out at that concentration, not a potency): 56.4%
Beside the measured number, compound 3's estimate is 21.4 percentage points below it; the range from low to high includes it.
By their numbers in this assay, from the lowest: compounds 2 and 3 (each within the scatter of the next); then compound 1.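

In this assay, this second exchange of 4-fluorophenyl to 4-methoxyphenyl gives a number 3.5 percentage points higher from compound 2 to compound 3 (within the scatter) and the first gave a number 37.7 percentage points lower from compound 1 to compound 2 (beyond the scatter) on the shared core. The same change therefore does not carry the same step at both places: only the first lies beyond the scatter, and a methoxy here leaves the read-out of compound 2 within the scatter. Nothing available accounts for this contrast.

Open, from the compounds shown here alone, is whether an amine or a carboxylic acid at this place would separate from methoxy, and whether a longer chain such as butoxy would do so.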